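The compounds below may be only part of what the source reports. "The series", "measured", "known", "first", "only" and "open" are said of these compounds alone.

Three compounds have been measured in a functional assay on NIH3T3 cells (Mus musculus) for inhibition, read by MTT assay, with a stated time of 72 h; a higher number here means a weaker inhibitor, a lower number a stronger inhibitor:

Compound 1, `C=C1CC[C@H]2[C@@](C)(CC[C@@H](O)[C@@]2(C)C(=O)OCc2ccccc2)[C@@H]1CCC1=CCOC1=O`: 37900 nM
Compound 2, `C=C1CC[C@H]2[C@@](C)(CC[C@@H](O)[C@@]2(C)C(=O)OCc2ccccn2)[C@@H]1CCC1=CCOC1=O`: 79800 nM
Compound 3, `C=C1CC[C@H]2[C@@](C)(CC[C@@H](OC(C)=O)[C@@]2(C)C(=O)OCc2ccccc2)[C@@H]1/C=C/C1=CCOC1=O`: 52700 nM

Compound 1 and compound 2 share one core and differ only by pyridin-2-yl in place of phenyl on a saturated chain carbon bound to an oxygen next to a carbonyl group. That single change gave a 2.1-fold higher number from compound 1 to compound 2 (0.32 log units; beyond the scatter), so compound 2 came out as the weaker inhibitor of the pair. Compound 3 carries a different core from compound 1; the difference between the two cores is not broken down here, and the two values lie close together.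

Compound 4, `C=C1CC[C@H]2[C@@](C)(CC[C@@H](OC(C)=O)[C@@]2(C)C(=O)OCc2ccccn2)[C@@H]1/C=C/C1=CCOC1=O`, has not yet been tested in this assay. It is built from compound 3 by pyridin-2-yl in place of phenyl on a saturated chain carbon bound to an oxygen next to a carbonyl group, the same change at the same place as that from compound 1 to compound 2. Going by the values given here, that earlier step is the only guide available. Because a 2.1-fold higher number from compound 1 to compound 2 (0.32 log units; beyond the scatter) was modest and carried the number upward, a step of similar size and direction is expected for compound 4, a 2.1-fold higher number from compound 3 to compound 4 (0.32 log units; beyond the scatter). In this assay compound 4 is therefore estimated at 110000 nM, most likely falling between 50000 nM and 250000 nM.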

Compound 4, half-maximal inhibitory concentration: 34900 nM
For compound 4 the middle estimate is 3.2-fold (0.50 log units) above the measured one; the measured number lies below the stated range.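

In this assay, putting pyridin-2-yl in place of phenyl gave a 1.5-fold lower number from compound 3 to compound 4 (0.18 log units; within the scatter), a step that stays within the ordinary spread of repeat measurements. Set beside the earlier step, this shows that the change did not act as a fixed shift that carries over from one core to the other: the same change on two cores in this assay, a 2.1-fold higher number (0.32 log units; beyond the scatter) from compound 1 to compound 2 and a 1.5-fold lower number (0.18 log units; within the scatter) from compound 3 to compound 4, 3.2-fold (0.50 log units) apart, beyond the scatter of two such steps. Going by these compounds alone, with only two pairs, it does not show which part of the difference between the two cores matters, nor how the same change would behave on a further core.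

The compounds shown leave open how a longer chain in place of benzyl, or a cyclohexyl ring in place of phenyl, would behave at this place. They also leave open what a carboxylic acid in place of benzyloxycarbonyl would do on either core.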